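A few compounds are considered here, and "the series" means these few. Any claim that something is new, unique, unknown or untested is made for them only; others in the source may bear on it.

Compound 1 `COc1ccc(/C(F)=C(/F)c2cc(OC)c(OC)c(OC)c2)cc1N` — 3600 nM
Compound 2 `COc1cc(/C(F)=C\c2cc(O)c3ccsc3c2)cc(OC)c1OC` — 23 nM
Compound 3 `COc1cc(/C=C\c2cc(O)c3ccoc3c2)cc(OC)c1OC` — 49 nM

All three were tested in a functional assay on cells (Endothelial cell, Bos taurus) for antiproliferative activity; a higher number here means a weaker inhibitor, a lower number a stronger inhibitor. Compound 3 gives the second highest of the three numbers, 49 nM; the nearest is compound 2 with a lower number, 23 nM, and the furthest is compound 1 with a much higher number, 3600 nM. Compound 4 `COc1cc(/C=C/c2cc(O)c3ccoc3c2)cc(OC)c1OC` has not yet been measured. Its difference from compound 3 is this: the two compounds have the same atoms and bonds and differ only in configuration as drawn: 1 of 1 stereo elements differ; a double bond is drawn Z in compound 3 and E in compound 4. Going by the values given here, no measured pair differs in only this way, so no comparable step is known. The expected step from compound 3 to compound 4 in this assay is a 61-fold higher number from compound 3 to compound 4 (1.79 log units; beyond the scatter), an increase well beyond the scatter. Compound 4 is accordingly estimated at 3000 nM, within a range from 500 nM to 20000 nM.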

Compound 4, half-maximal inhibitory concentration: 27000 nM
Beside the measured number, compound 4's estimate is 9.0-fold (0.95 log units) below it, and the stated range ends below it.
By their numbers in this assay, from the lowest: compound 2; then compound 3; then compound 1; then compound 4.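

In this assay, redrawing the double bond from Z to E, with nothing else changed, gives a 550-fold higher number from compound 3 to compound 4 (2.74 log units; beyond the scatter). The earlier compounds offered no comparison of a single change, whereas this large step can be assigned to the geometry of the double bond alone, because nothing else separates the pair: the fact that compounds 3 and 4 differ only in the configuration as drawn

Going by these compounds, it remains open whether the same geometry step would appear with the fluorine on the double bond of compound 2, or with a carboxylic acid in place of the hydroxyl group of compound 3. These compounds also cannot say why the Z form gives the lower number.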